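Swapping the aryl group for a morpholine amide

The compounds below may be only part of what the source reports. "The series", "measured", "known", "first", "only" and "open" are said of these compounds alone.

Measured compounds in an assay (Rattus norvegicus) for inhibition of Fatty-acid amide hydrolase 1 (Homo sapiens); on this read-out higher numbers stand for weaker inhibition and lower numbers for stronger inhibition:
compound 1 `O=C(CCCCCCc1ccccc1)c1ncc(-c2cccc(O)c2)o1`: 50 nM
compound 2 `COc1ccc(-c2cnc(C(=O)CCCCCCc3ccccc3)o2)cc1`: 100 nM
compound 3 `O=C(CCCCCCc1ccccc1)c1ncc(-c2ncccc2C(=O)O)o1`: > 50 nM

For compound 3 the value shown is only a limit of this assay, not a number. One of the three values sits at that limit (the limit of > 50 nM in this assay, at which 1 of the 3 values shown sits). Compound 4 `O=C(CCCCCCc1ccccc1)c1ncc(C(=O)N2CCOCC2)o1` differs from compound 3 in one place: (morpholin-4-yl)carbonyl in place of 3-carboxypyridin-2-yl on an aromatic carbon. Of the measured steps, a 2.0-fold higher number from compound 1 to compound 2 (0.30 log units; within the scatter) is the only one with a readable size; the steps of a number no lower from compound 1 to compound 3 (the limit leaves the size open) and a step that the limit leaves unreadable from compound 2 to compound 3 give no size. For the measured compounds named here, none of them exchange an aromatic group for a non-aromatic amide, so no measured step tells the size of this one. Compound 4 is expected to be a weaker inhibitor, with an estimated step that the limit leaves unreadable from compound 3 to compound 4. Compound 4 is estimated at 400 nM, between 60 nM and 3000 nM.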

Compound 4, inhibition constant: 24 nM
For compound 4 the middle estimate is 17-fold (1.22 log units) above the measured one; the whole stated range lies above it.
By their numbers in this assay, from the lowest: compound 4; then compounds 1 and 2 (each within the scatter of the next).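

This position does not need an aromatic group: with (morpholin-4-yl)carbonyl there, a non-aromatic amide, the measured steps are a 4.2-fold lower number from compound 2 to compound 4 (0.62 log units; beyond the scatter) and a 2.1-fold lower number from compound 1 to compound 4 (0.32 log units; beyond the scatter). Exchanging the 3-carboxypyridin-2-yl group for the same amide gives an at least 2.0-fold lower number from compound 3 to compound 4 (0.31 log units; beyond the scatter). That step rests on a value for compound 3 that is only a limit: the limit of > 50 nM in this assay, at which 1 of the 4 values shown sits.

From the compounds shown here alone, what stays open is whether any amide at this place would do, or only the morpholine one. A piperidine amide or a dimethylamide here would speak to that.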